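Inverting the quaternary fluoro acid centre of compound 3

The source may hold more compounds than are shown below. What is called first, only, known or untested is meant among the compounds shown, and "the series" means these compounds.

Among the compounds with values here, compound 3 `COc1ccc(F)c([C@H]2CC[C@H](COc3cccc([C@H](C4CC4)[C@@](C)(F)C(=O)O)c3)CC2)c1` gives 0.25 nM in a functional assay on HEK293 cells for agonist activity at Free fatty acid receptor 1 (Homo sapiens), read by FLIPR and calcium flux (a lower number here means that less compound is needed, a higher number that more compound is needed for the effect), the lowest of the three numbers so far. Compound 1 `COc1ccc(F)c([C@H]2CC[C@H](COc3cccc([C@H](C4CC4)[C@@H](C)C(=O)O)c3)CC2)c1` gives 2.2 nM in this assay, and compound 2 `COc1ccc(F)c([C@H]2CC[C@H](COc3cccc([C@H](C4CC4)[C@@H](F)C(=O)O)c3)CC2)c1` gives 1.1 nM. The step of a 2.0-fold lower number from compound 1 to compound 2 (0.30 log units; within the scatter) is small, whereas an 8.8-fold lower number from compound 1 to compound 3 (0.94 log units; beyond the scatter) and a 4.4-fold lower number from compound 2 to compound 3 (0.64 log units; beyond the scatter) set compound 3 apart from both at a modest margin.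

Compound 4 `COc1ccc(F)c([C@H]2CC[C@H](COc3cccc([C@H](C4CC4)[C@](C)(F)C(=O)O)c3)CC2)c1` is the next compound. Relative to compound 3, (the two compounds have the same atoms and bonds and differ only in configuration as drawn: 1 of 4 stereo elements differ; a stereocentre at a saturated chain carbon is drawn R in compound 3 and S in compound 4). The stereocentre concerned is the saturated chain carbon bound to a carbonyl carbon and two saturated chain carbons.

Within the data shown here, no measured step bears directly on this change: all three steps alter the groups on that carbon while keeping its drawn configuration, and no number exists for the other configuration of any compound. The expectation therefore rests only on the fact that every gain so far was recorded with the configuration drawn in compound 3, and is held loosely. Compound 4 is expected to give a higher number than compound 3, with the step of a 12-fold higher number from compound 3 to compound 4 (1.08 log units; beyond the scatter) uncertain in size. Compound 4 is estimated at 3 nM, within a range from 0.4 nM to 25 nM.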

Compound 4, half-maximal effective concentration: 6.1 nM
For compound 4 the middle estimate is 2.0-fold (0.31 log units) below the measured one; measured number inside the range.
By their numbers in this assay, from the lowest: compound 3; then compounds 2 and 1 (each within the scatter of the next); then compound 4.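

In this assay, the configuration at the carbon carrying the fluoro, methyl and carboxyl groups outweighs every change of group made there so far: a 24-fold higher number from compound 3 to compound 4 (1.39 log units; beyond the scatter) is the largest step in the series. The effect of a group at this carbon also depends on that configuration: adding methyl gives a 4.4-fold lower number from compound 2 to compound 3 (0.64 log units; beyond the scatter) in one configuration but a 5.5-fold higher number from compound 2 to compound 4 (0.74 log units; beyond the scatter) in the other, and replacing hydrogen with fluoro gives an 8.8-fold lower number from compound 1 to compound 3 (0.94 log units; beyond the scatter) in one but a 2.8-fold higher number from compound 1 to compound 4 (0.44 log units; beyond the scatter) in the other, so the quaternary fluoro acid is not favourable in itself. The gap between the two quaternary compounds can be assigned to this one stereocentre alone because of a single structural fact: the fact that compounds 3 and 4 differ only in the configuration as drawn.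

The compounds shown leave open whether inversion at this carbon would cost as much in the methyl acid of compound 1 or the fluoro acid of compound 2. They also leave open whether the same preference would hold with a hydroxyl or an ethyl group in place of the fluoro.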